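Replacing 4-methylphenyl on compound 3

The compounds below may be only part of what the source reports. "The series", "measured", "known", "first", "only" and "open" are said of these compounds alone.

Compound 1 `Cc1ccc(-c2cc(C(=O)Nc3cccnc3)c3cc(Br)ccc3n2)cc1`: 39000 nM
Compound 2 `Cc1ccc(-c2cc(C(=O)NCCCN(C)C)c3cc(Cl)ccc3n2)cc1`: 262000 nM
Compound 3 `Cc1ccc(-c2cc(C(=O)NCCN3CCCC3)c3cc(Cl)ccc3n2)cc1`: 13000 nM

These three compounds were tested in a physicochemical assay for solubility, read by nephelometry, measured as kinetic solubility; a higher number here means a more soluble compound, a lower number a less soluble compound. Compound 3, at 13000 nM, stands lowest of the three, with compound 1 at 39000 nM and compound 2 at 262000 nM.

Compound 4 `O=C(NCCN1CCCC1)c1cc(NCCC2CCOCC2)nc2ccc(Cl)cc12` keeps the amide side chain of compound 3 and changes one other place: (2-(oxan-4-yl)ethyl)amino in place of 4-methylphenyl on an aromatic carbon. In words, (2-(oxan-4-yl)ethyl)amino stands in place of 4-methylphenyl on an aromatic carbon, next to the ring nitrogen.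

Only one measured step links two of these compounds: a 20-fold lower number from compound 2 to compound 3 (1.30 log units; beyond the scatter). That step is large, but it lies in the side chain, so it gives no direct size for the new swap. Within the data shown here, it shows only that a single change can move this read-out a long way. Among the measured compounds shown here, no measured step touches the place that changes now, so the expectation is uncertain. A ring of carbon only leaves, and a group with a hydrogen-bond donor and acceptors enters. A clearly higher number in this assay is therefore expected, though a step within the scatter remains possible. The expected step is a 3.8-fold higher number from compound 3 to compound 4 (0.59 log units; beyond the scatter). For compound 4 the estimated value is 50000 nM, with an expected range of 13000 nM to 200000 nM.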

Compound 4, solubility: 230000 nM
The estimate for compound 4 lay 4.6-fold (0.66 log units) below the measured number; the whole stated range lies below it.
By their numbers in this assay, from the lowest: compound 3; then compound 1; then compounds 4 and 2 (each within the scatter of the next).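

In this assay, putting (2-(oxan-4-yl)ethyl)amino in place of 4-methylphenyl on the aromatic carbon next to the ring nitrogen gives an 18-fold higher number from compound 3 to compound 4 (1.25 log units; beyond the scatter) with the amide side chain held the same. The earlier compounds shown here showed a large step only in that side chain, so this result adds a second place on the molecule where one change moves the read-out a long way. The swap alters several things at once, since an aromatic ring of carbon only leaves while a non-aromatic ring, a nitrogen, an oxygen and hydrogen-bond donor and acceptor atoms enter, and no supporting measurement here says which of these matters.

The compounds shown leave open which part of the new group carries the step: (2-cyclohexylethyl)amino would keep the chain and the nitrogen without the ring oxygen, while a simple ethylamino group would keep the nitrogen without any ring. Going by these compounds, it also remains open whether the same swap gives a step of similar size on the amide side chain of compound 2.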